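The compounds below may be only part of what the source reports. "The series", "measured", "known", "first", "only" and "open" are said of these compounds alone.

Three compounds have been measured in a functional assay on MKN-74 cells (Homo sapiens) for antiproliferative activity, with a stated time of 24 h; a lower number here means a stronger inhibitor, a higher number a weaker inhibitor:

- compound 1, `NC(=O)c1c(NC(=O)c2ccccc2Cl)sc2c1CCN(C(=O)Nc1ccccc1Cl)C2`, gives 16300 nM
- compound 2, `NC(=O)c1c(NC(=O)c2ccccc2F)sc2c1CCN(C(=O)Nc1ccccc1Cl)C2`, gives 49600 nM
- compound 3, `Cc1ccc(C(=O)Nc2sc3c(c2C(N)=O)CCN(C(=O)Nc2ccccc2Cl)C3)cc1`, gives 27600 nM

All three share the same core and differ only in the aromatic ring attached to the carbonyl carbon of the amide. On the numbers shown, compound 3 sits second highest of the three, with compound 1 as its nearest neighbour and compound 2 as the furthest, and both of those gaps fall within the usual scatter of repeated measurements.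

Compound 4, `NC(=O)c1c(NC(=O)c2cccc([N+](=O)[O-])c2)sc2c1CCN(C(=O)Nc1ccccc1Cl)C2`, has not yet been measured. It differs from compound 3 in one place: 3-nitrophenyl in place of 4-methylphenyl on a carbonyl carbon. Within the data shown here, the measured steps that bear on this are the two that swap the aryl group on the carbonyl carbon, a 1.7-fold higher number from compound 1 to compound 3 (0.23 log units; within the scatter) and a 1.8-fold lower number from compound 2 to compound 3 (0.25 log units; within the scatter), neither of which left the scatter, and the single step that did, a 3.0-fold higher number from compound 1 to compound 2 (0.48 log units; beyond the scatter), which was modest. Among the measured compounds shown here, no measured step places a nitro group on this ring, so there is nothing to suggest a shift beyond the scatter in this assay.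

Compound 4 is therefore expected to land close to compound 3, with an estimated step of a 1.1-fold higher number from compound 3 to compound 4 (0.04 log units; within the scatter), giving an estimate of 30000 nM within a range of 10000 nM to 90000 nM.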

Compound 4, half-maximal inhibitory concentration: 22700 nM
Estimate against measurement, compound 4: 1.3-fold (0.12 log units) above, and the stated range covers the measured number.
By their numbers in this assay, from the lowest: compounds 1, 4, 3 and 2 (each within the scatter of the next, the first and the last beyond it).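

In this assay a nitro group can stand on the aryl ring on this carbonyl carbon with no shift beyond the scatter, whether 3-nitrophenyl is set against 4-methylphenyl (a 1.2-fold lower number from compound 3 to compound 4 (0.08 log units; within the scatter)) or against 2-chlorophenyl (a 1.4-fold higher number from compound 1 to compound 4 (0.14 log units; within the scatter)). Among these compounds, the one step from compound 4 that leaves the scatter is modest (a 2.2-fold lower number from compound 2 to compound 4 (0.34 log units; beyond the scatter)), so compound 2, with its 2-fluorophenyl, now differs from two of the other aryl groups, although compound 3 goes against a clean separation, since its step from compound 2 stays within the scatter. No measurement shown gives a reason for these differences or for how little the number moves across such unlike aryl groups.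

The compounds shown leave open whether an amine or a carboxylic acid on this aryl ring, or a longer alkyl chain in place of the ring, would move the number further than the aryl groups so far. They also leave open whether 3-nitrophenyl and the other aryl groups would keep these close numbers with anything other than the shared core and the rest of the structure held constant.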